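The compounds below may be only part of what the source reports. "The series", "measured", "known", "first", "only" and "open" are said of these compounds alone.

Compound 2 `O=C(NCCCCN1CCN(c2ccc(Cl)cc2)CC1)c1ccc(-c2ccsc2)cc1` carries a 4-chlorophenyl group on the ring nitrogen and gives the highest of the three half-lives measured in an ADME assay on microsomes from liver (Rattus norvegicus) for metabolic stability, read by LC-MS, using NADPH (a lower number here means that the compound disappears faster, a higher number that the compound lasts longer), namely 0.837 h. Compound 1 `O=C(NCCCCN1CCN(c2cccc(Cl)c2)CC1)c1ccc(-c2ccsc2)cc1` with its 3-chlorophenyl group gives 0.468 h, and the step of a 1.8-fold higher number from compound 1 to compound 2 (0.25 log units; within the scatter) stays within the scatter. Compound 3 `COc1ccccc1N1CCN(CCCCNC(=O)c2ccc(-c3ccsc3)cc2)CC1` with a 2-methoxyphenyl group gives 0.04 h, a short half-life, and the steps of a 12-fold lower number from compound 1 to compound 3 (1.07 log units; beyond the scatter) and a 21-fold lower number from compound 2 to compound 3 (1.32 log units; beyond the scatter) are both large and beyond the scatter.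

The new compound 4 `COc1cccc(N2CCN(CCCCNC(=O)c3ccc(-c4ccsc4)cc3)CC2)c1` is related to compound 2 by the change (3-methoxyphenyl in place of 4-chlorophenyl on an amine nitrogen in a ring). Among the compounds with values here, no measured step exchanges a chlorophenyl for a 3-methoxyphenyl, so the closest guide is the step of a 21-fold lower number from compound 2 to compound 3 (1.32 log units; beyond the scatter), which replaces the same 4-chlorophenyl with a methoxyphenyl of a different substitution pattern. Within the data shown here, since the methoxyphenyl in compound 3 sits in a different place on the ring than the one in compound 4, the full size of that drop need not carry over, but a clear decrease beyond the scatter is expected, because a 21-fold lower number from compound 2 to compound 3 (1.32 log units; beyond the scatter) was large. The expected step is therefore a 5.6-fold lower number from compound 2 to compound 4 (0.75 log units; beyond the scatter).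

For compound 4 the half-life in this assay is estimated at 0.15 h, with a likely range from 0.05 h to 0.5 h.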

Compound 4, half-life: 0.155 h
Compound 4: middle estimate off by 1.0-fold (0.01 log units), on the low side; measured number inside the range.
By their numbers in this assay, from the lowest: compound 3; then compound 4; then compounds 1 and 2 (each within the scatter of the next).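

In this assay, the 3-methoxyphenyl group shows that the place of the methoxy group on the phenyl ring counts, and not only its presence: the step to it from the 2-methoxyphenyl group is a 3.9-fold higher number from compound 3 to compound 4 (0.59 log units; beyond the scatter). Moving to the 3-methoxyphenyl group does not close the gap to the chlorophenyl compounds, as shown by a 5.4-fold lower number from compound 2 to compound 4 (0.73 log units; beyond the scatter) and by a 3.0-fold lower number from compound 1 to compound 4 (0.48 log units; beyond the scatter), the latter being the one comparison in which methoxy replaces chloro while the place on the phenyl ring stays the same, so across these four compounds both methoxyphenyl compounds lie beyond the scatter below both chlorophenyl compounds, and none goes against this. Nothing available explains these differences in half-life.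

The compounds shown leave open how a 4-methoxyphenyl or a 2-chlorophenyl group would behave, and so whether methoxy and chloro differ in the same direction at every place on the ring. They also leave open what a fluorophenyl, a trifluoromethylphenyl or a nitrile-bearing phenyl group on the same ring nitrogen would give, or how a shorter chain would change the half-life.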